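A few compounds are considered here, and "the series" means these few. Any claim that something is new, unique, unknown or untested is made for them only; others in the source may bear on it.

The measured compounds:

compound 1, `CCCS(=O)(=O)Nc1ccc(F)c(C(=O)c2n[nH]c3ncc(-c4cccc(O)c4)cc23)c1F`, 2.2%
compound 2, `CCCS(=O)(=O)Nc1ccc(F)c(C(=O)c2n[nH]c3ncc(-c4ccccc4N)cc23)c1F`, 23%
compound 3, `CCCS(=O)(=O)Nc1ccc(F)c(C(=O)c2n[nH]c3ncc(-c4ccc(Cl)c(Cl)c4)cc23)c1F`, 45%

In an assay for binding affinity to dual specificity mitogen-activated protein kinase kinase 4 (Homo sapiens), read by KINOMEscan, tested at 100 nM (on this read-out higher numbers stand for a weaker effect at the one concentration tested and lower numbers for a stronger effect), compound 1 gives 2.2% and stands lowest of the three numbers, so at this one concentration it shows the strongest effect: compound 2 lies a number 20.8 percentage points higher from compound 1 to compound 2 (beyond the scatter) away and compound 3 lies a number 42.8 percentage points higher from compound 1 to compound 3 (beyond the scatter) away, both beyond the scatter. Between the other two, compound 3 sits a number 22 percentage points higher from compound 2 to compound 3 (beyond the scatter) from compound 2.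

Compound 4, `CCCS(=O)(=O)Nc1ccc(F)c(C(=O)c2n[nH]c3ncc(-c4ccc(S(=O)(=O)NC)cc4)cc23)c1F`, has not yet been measured. It differs from compound 1 in one place: 4-(methylsulfamoyl)phenyl in place of 3-hydroxyphenyl on an aromatic carbon.

For the measured compounds named here, two measured steps bear on this change, since both also replace the 3-hydroxyphenyl of compound 1 with a different substituted phenyl on the same aromatic carbon. Those steps were a number 20.8 percentage points higher from compound 1 to compound 2 (beyond the scatter) and a number 42.8 percentage points higher from compound 1 to compound 3 (beyond the scatter), one modest and one large, and both went in the direction of a weaker effect. Neither of the entering groups there matches the 4-(methylsulfamoyl)phenyl of compound 4, so the size is uncertain, but a rise in the number in this assay beyond the scatter is expected.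

Compound 4 is therefore estimated at 25%, with a range from 5% to 60%. The expected step is a number 22.8 percentage points higher from compound 1 to compound 4 (beyond the scatter).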

Compound 4, a percentage reported as activity, at one concentration (the size of the read-out at that concentration, not a potency): 1.2%
For compound 4 the middle estimate is 23.8 percentage points above the measured one; measured number outside the range, below it.
By their numbers in this assay, from the lowest: compounds 4 and 1 (each within the scatter of the next); then compound 2; then compound 3.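

In this assay the step to the 4-(methylsulfamoyl)phenyl group, a number 1 percentage points lower from compound 1 to compound 4 (within the scatter), shows that a low number at this position does not depend on the 3-hydroxyphenyl group, even though both earlier replacements had raised the number beyond the scatter. The same group also stands apart from the other two replacements on this carbon, with a number 43.8 percentage points lower from compound 3 to compound 4 (beyond the scatter) and a number 21.8 percentage points lower from compound 2 to compound 4 (beyond the scatter), so among these four compounds the number depends strongly on which substituted phenyl sits at this place, and a larger group here does not by itself raise it. No measurement shown here accounts for these differences.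

The compounds shown leave open whether the methylsulfamoyl group needs its nitrogen-bound hydrogen or its methyl, which a dimethylsulfamoyl, an unsubstituted sulfamoyl or a carboxylic acid on the same phenyl would test. They also leave open how compound 1 and compound 4 compare in potency, since a read-out at one concentration gives no potency and their numbers lie within the scatter of each other.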